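A few compounds are considered here, and "the series" means these few. Any claim that something is new, unique, unknown or untested is made for them only; others in the source may bear on it.

Compound 1 `CCCn1cc(C(N)=O)c2c(N)ncnc21` and compound 2 `CCCn1cc(C(=N)S)c2c(N)ncnc21` share one core and differ in a single group on an aromatic carbon. In a functional assay on KB cells (Homo sapiens) for cytotoxicity (on this read-out higher numbers stand for weaker inhibition and lower numbers for stronger inhibition), compound 1 gives 100000 nM, while compound 2 gives 17000 nM, the lower of the two numbers, reached by a 5.9-fold lower number from compound 1 to compound 2 (0.77 log units; beyond the scatter). Compound 3 `CCOCn1cc(C(=N)S)c2c(N)ncnc21` keeps that group of compound 2 and instead alters the chain on the aromatic nitrogen: ethoxy in place of ethyl on a saturated chain carbon bound to an aromatic nitrogen. Going by the values given here, no measured step touches this chain; the only step measured, from compound 1 to compound 2, concerns a different place and offers no guide to the size or direction of this one. With nothing to lean on, compound 3 is expected to stay close to its parent, with an estimated step of no change at the digits printed from compound 2 to compound 3 (within the scatter), which would be none beyond the scatter. Compound 3 is therefore estimated at 17000 nM in this assay, with a range from 5000 nM to 60000 nM.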

Compound 3, half-maximal inhibitory concentration: 68000 nM
For compound 3 the middle estimate is 4.0-fold (0.60 log units) below the measured one; the measured number lies above the stated range.
By their numbers in this assay, from the lowest: compound 2; then compounds 3 and 1 (each within the scatter of the next).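

In this assay, the chain on the aromatic nitrogen proves to be a place where a small edit can be read: ethoxy in place of ethyl on the saturated chain carbon gives a 4.0-fold higher number from compound 2 to compound 3 (0.60 log units; beyond the scatter). This shows that the position is not indifferent to change, and that this particular edit, which adds one oxygen and one hydrogen-bond acceptor, moves the number toward weaker inhibition. Nothing in the available data explains why the number shifts this way.

A butyl chain on the aromatic nitrogen would help tell whether the oxygen or the chain length goes with this step, and an amine on that chain would test a different kind of group at the same place. On these data alone, it also remains open whether ethoxymethyl would shift the number similarly with the amide of compound 1 in place of the group shared by compound 2 and compound 3.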